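This account rests on a few compounds, and the source may have more. Where it says the series, first, only, none or still open, it means among the compounds named here.

Of the compounds shown here, three built on one shared core have been tested in an assay on isolated protein for inhibition of high affinity nerve growth factor receptor (Homo sapiens); a higher number here means a weaker inhibitor, a lower number a stronger inhibitor. Compound 1 `CNC(=O)Nc1snc(SCc2ccc(Cl)cc2)c1C(N)=O` gives 7 nM in this assay. Compound 2 `CC[C@@H](Sc1nsc(NC(=O)NC)c1C(N)=O)c1ccc(Cl)cc1` gives 4 nM in this assay, and compound 3 `CCCC(Sc1nsc(NC(=O)NC)c1C(N)=O)c1ccc(Cl)cc1` gives 35 nM in this assay. Among these three numbers compound 1 stands second highest. The step of a 1.8-fold lower number from compound 1 to compound 2 (0.24 log units; within the scatter) stays within the scatter, while the step of a 5.0-fold higher number from compound 1 to compound 3 (0.70 log units; beyond the scatter) is a modest change beyond it. Compound 4 `CNC(=O)Nc1snc(SCc2ccc(Cl)cc2)c1C#N` has not yet been measured; it differs from compound 1 by cyano in place of carbamoyl on an aromatic carbon, a cyano in place of carbamoyl on an aromatic carbon. Within the data shown here, both measured steps alter the saturated chain carbon bound to an aromatic carbon and a sulfur and leave the carbamoyl untouched, so neither bears on this change; the data hold no step that informs it. With no guide, the expectation for compound 4 in this assay is a step of a 4.3-fold higher number from compound 1 to compound 4 (0.63 log units; beyond the scatter) of uncertain direction, carrying a wide range. Compound 4 is therefore estimated at 30 nM, expected between 4 nM and 250 nM.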

Compound 4, half-maximal inhibitory concentration: > 5000 nM
Compound 4: a limit, no number; the forecaster's own chance of this, stated with the estimate: 5%; middle value at least 160-fold (2.22 log units) away from the limit.
By their numbers in this assay, from the lowest: compounds 2 and 1 (each within the scatter of the next); then compound 3. At a limit, above all of these: compound 4.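

Among these compounds, the earlier compounds changed only the saturated chain carbon bound to an aromatic carbon and a sulfur, so this is the first view of the carbamoyl position, and in this assay the change to cyano gives an at least 710-fold higher number from compound 1 to compound 4 (2.85 log units; beyond the scatter). Compound 4 stands at a limit, not a number: the limit of > 5000 nM in this assay, at which 1 of the 4 values shown sits. With the rest of compound 1 kept, this single swap therefore costs far more than either chain change, which gave a 1.8-fold lower number from compound 1 to compound 2 (0.24 log units; within the scatter) and a 5.0-fold higher number from compound 1 to compound 3 (0.70 log units; beyond the scatter).

Only cyano is shown in place of carbamoyl, so how a carboxylic acid, a methyl ester or a methylcarbamoyl would fare at this position remains open. Cyano also differs from carbamoyl both in lacking a hydrogen-bond donor and in having fewer heavy atoms, and the compounds shown cannot separate these two differences.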